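The source may report more compounds than this note shows. Statements on the series, on what has been measured and on what is new or still open speak of the compounds shown alone.

Compound 1 `COCCNC(=O)c1cc2cccc(OC)c2oc1=N` gives > 70% in an assay on CHO cells for displacement of a labelled ligand from adenosine receptor A1 (Homo sapiens), read by scintillation counting, with a stated time of 60 min, tested at 10 uM; a higher number here means more inhibition at the concentration tested (going by the name of the read-out), a lower number less inhibition; this is a limit of the measurement, not a number.
Compound 2 `CCC(CO)NC(=O)c1cc2cccc(OC)c2oc1=N` gives 24% in this assay.

Among the measured compounds shown here, compound 2 thus holds the only number among the two values shown; the other sits at a limit (the limit of > 70% in this assay, at which 1 of the 2 values shown sits). For the measured compounds named here, the single measured step, a number at least 46 percentage points lower from compound 1 to compound 2 (beyond the scatter), is large. Compound 3 `COc1cccc2cc(C(=O)NC(CO)(CO)CO)c(=N)oc12` differs from compound 2 by 2-hydroxy-1,1-bis(hydroxymethyl)ethyl in place of 1-(hydroxymethyl)propyl on an amide-type nitrogen. Going by the values given here, no measured step covers that exchange; the one step bears on it only loosely, showing that a branched hydroxyl-bearing group in place of 2-methoxyethyl cut inhibition strongly. A step of a number 9 percentage points lower from compound 2 to compound 3 (within the scatter) is expected, not beyond the scatter, downward if anything. Compound 3 is estimated at 15%, between 0% and 40%.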

Compound 3, a percentage reported as inhibition, at one concentration (the size of the read-out at that concentration, not a potency): 19%
Compound 3: middle estimate off by 4 percentage points, on the low side; measured number inside the range.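

In this assay, 2-hydroxy-1,1-bis(hydroxymethyl)ethyl in place of 1-(hydroxymethyl)propyl on the amide-type nitrogen gives a number 5 percentage points lower from compound 2 to compound 3 (within the scatter), so adding hydroxymethyl in place of the ethyl branch leaves the read-out unresolved from compound 2. In place of 2-methoxyethyl, the same group gives a number at least 51 percentage points lower from compound 1 to compound 3 (beyond the scatter), a second branched hydroxyl-bearing group far from compound 1. The size of that step is open on one side, as compound 1 sits at a limit: the limit of > 70% in this assay, at which 1 of the 3 values shown sits.

Open, from the compounds shown here alone, is whether the branching or the free hydroxyl separates these groups from 2-methoxyethyl. A straight 2-hydroxyethyl chain, a longer methoxyalkyl chain or an amine at this nitrogen would bear on that.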